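This account rests on a few compounds, and the source may have more. Where it says the series, first, only, none or still open, it means among the compounds named here.

For the measured compounds named here, in an assay on NK92 cells for inhibition of interleukin-15 (Homo sapiens), read by AlphaScreen, with stated times of 30 min and 1 h (a lower number here means a stronger inhibitor, a higher number a weaker inhibitor), compound 1 `CCOC(CCn1c(Cc2nn(C)c(=O)c3ccccc23)nnc1SCCCCCCCC(=O)Nc1ccc(Cl)cc1Cl)OCC` gives 30000 nM, the higher of the two numbers measured so far. Its nearest neighbour is compound 2 `Cn1nc(Cc2nnc(SCC(=O)Nc3ccc(Cl)cc3Cl)n2CCC=O)c2ccccc2c1=O`, which in this assay gives 4200 nM, a value separated from that of compound 1 by more than the usual scatter. Compound 3 `Cn1nc(Cc2nnc(SCC(=O)Nc3ccc(Cl)cc3Cl)n2CCC(=O)O)c2ccccc2c1=O` gives > 30000 nM in this assay, and this is a limit of the assay rather than a number. Going by the values given here, the one single-point step measured so far, an at least 7.1-fold higher number from compound 2 to compound 3 (0.85 log units; beyond the scatter), shows that changing the chain on the aromatic nitrogen can push the number up markedly. Compound 4 `Cn1nc(Cc2nnc(SCCCCCCCC(=O)Nc3ccc(Cl)cc3Cl)n2CCCO)c2ccccc2c1=O` differs from compound 1 in that same chain: hydroxymethyl in place of diethoxymethyl on a saturated chain carbon, two bonds along the chain from an aromatic nitrogen. Among the compounds with values here, no measured step covers this exact exchange, so the step from compound 2 to compound 3 is only a loose guide; it concerns a different group on the chain and made the number higher. Compound 1 already sits close to the limit at which one of the three values stands (the limit of > 30000 nM in this assay, at which 1 of the 3 values shown sits), so a number may not be obtained at all. The step from compound 1 to compound 4 is expected to be a 1.5-fold lower number from compound 1 to compound 4 (0.18 log units; within the scatter), essentially no shift beyond the scatter. Compound 4 is therefore estimated at 20000 nM in this assay, within 5000 nM to 60000 nM.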

Compound 4, half-maximal inhibitory concentration: > 30000 nM
Compound 4: no number, only a limit; the forecaster's own chance of this, stated with the estimate: 40%; middle value at least 1.5-fold (0.17 log units) from the limit.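

In this assay compound 4 gives > 30000 nM, which is a limit of the assay and not a number. The exchange of 3,3-diethoxypropyl for 3-hydroxypropyl thus gives a number no lower from compound 1 to compound 4 (the limit leaves the size open), and the size of this step cannot be read, but it does show that the smaller group, with a hydrogen-bond donor where the old group had none, brings no measurable gain at this position. Each of the two single-place changes at the end of this chain that put a hydroxy group there, one in compound 3 and one in compound 4, now ends at the limit, whereas compound 1 and compound 2, which carry no hydroxy group, give numbers: the limit of > 30000 nM in this assay, at which 2 of the 4 values shown sit.

The compounds shown leave open whether an amine or a methyl ether at the end of the 3-hydroxypropyl chain would return a number in this assay. They also leave open whether 3-hydroxypropyl would give the same result on compound 2, where the rest of the molecule differs from that of compound 4.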